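The source may hold more compounds than are shown below. What is called first, only, known or untested is meant among the compounds shown, and "the series" means these compounds.

Among the compounds with values here, in a functional assay on HCT-116 cells (Homo sapiens) for antiproliferative activity, read by MTT assay, with a stated time of 72 h (a higher number here means a weaker inhibitor of growth, a lower number a stronger inhibitor of growth), compound 2 (`COc1cc(OC)c(/C=C/S(=O)(=O)Cc2cnc(OC)cn2)c(OC)c1`) gives 950 nM and holds the only true number so far. Compound 1 (`COc1cc(OC)c(/C=C/S(=O)(=O)Cc2cnc(Cl)cn2)c(OC)c1`) stands at > 10000 nM as a limit of the assay. Compound 3 (`COc1cc(OC)c(/C=C/S(=O)(=O)Nc2ccc(Cl)cc2)c(OC)c1`) stands at > 10000 nM as a limit too. The weak end of the series is thus marked by the limit of > 10000 nM in this assay, at which 2 of the 3 values shown sit, and not by numbers.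

Compound 4 (`COc1cc(OC)c(/C=C/S(=O)(=O)Cc2nc(Cl)ncc2OC)c(OC)c1`) carries 2-chloro-5-methoxypyrimidin-4-yl in place of 5-methoxypyrazin-2-yl on a saturated chain carbon bound to a sulfonyl sulfur.

The step that bears most is an at least 10-fold lower number from compound 1 to compound 2 (1.02 log units; beyond the scatter) with methoxy in place of chloro on an aromatic carbon. The other step, a step that the two limits leave unreadable from compound 1 to compound 3 as its size, gives no guidance. Compound 4 keeps a methoxy but carries a chloro again, so a weaker reading is expected in this assay though not the full size of that first step.

The estimated change is a 3.2-fold higher number from compound 2 to compound 4 (0.50 log units; beyond the scatter) as a moderate rise in the number. For compound 4 the expected value is 3000 nM with an estimated range from 700 nM to 10000 nM and a reading at the limit remains possible.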

Compound 4, concentration for 50% growth inhibition: > 10000 nM
Compound 4: only a limit was reported; the forecaster's own chance of this, stated with the estimate: 30%; middle value at least 3.3-fold (0.52 log units) away from the limit.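

In this assay, 2-chloro-5-methoxypyrimidin-4-yl in place of 5-methoxypyrazin-2-yl on a saturated chain carbon bound to a sulfonyl sulfur gives an at least 10-fold higher number from compound 2 to compound 4 (1.02 log units; beyond the scatter), so a methoxy on the ring does not by itself preserve the activity of compound 2. The chloro and the change of ring enter together in this single step, and their shares cannot be separated. Compound 4 gives a limit and not a number, and it joins the weak end of the series: the limit of > 10000 nM in this assay, at which 3 of the 4 values shown sit.

The step between compound 1 and compound 4 joins two limits and cannot be read. As far as these compounds go, it remains open whether the chloro or the rest of the 2-chloro-5-methoxypyrimidin-4-yl group carries the loss, and whether an amine or a methyl in place of that chloro would return a measurable number.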